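The source may hold more compounds than are shown below. What is called first, only, known or untested is meant among the compounds shown, and "the series" means these compounds.

Working notes on the series around compound 1 `C=CCNc1nc(N)c(C(=O)N=C(N)N)nc1Cl`. In an assay for inhibition of acid-sensing ion channel 3 (Homo sapiens), read by patch clamp, tested at 20 uM (on this read-out lower numbers stand for less inhibition and higher numbers for more inhibition at the one concentration tested (going by the name of the read-out)), compound 1 gives 78%, the lowest of the three values seen so far. Compound 2 `NC(N)=NC(=O)c1nc(Cl)c(NCc2ccc(Cl)cc2)nc1N` gives 97% and compound 3 `NC(N)=NC(=O)c1nc(Cl)c(NCc2ccc3ccccc3c2)nc1N` gives 93%; both sit above compound 1 by more than the scatter, so compound 1 has the lowest inhibition of the three on this read-out.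

For the measured compounds named here, the one single-point step measured so far is a number 19 percentage points higher from compound 1 to compound 2 (beyond the scatter). It replaces the vinyl end of the allyl chain with an aromatic ring, so it speaks to adding a ring on that chain, not to exchanging one open chain for another.

Compound 4 `CC(C)(C)Nc1nc(N)c(C(=O)N=C(N)N)nc1Cl` differs from compound 1 in one place: tert-butyl in place of allyl on a nitrogen on an aromatic ring. Going by the values given here, nothing measured here involves a saturated branched group on that nitrogen; the only step that bears on the site at all, from compound 1 to compound 2, brought in a ring, which compound 4 does not. With no ring entering and the heavy-atom count almost unchanged, no step beyond the scatter is expected in this assay, in either direction. Compound 4 is therefore estimated at 76%, with a range of 55% to 92%, meaning an expected step of a number 2 percentage points lower from compound 1 to compound 4 (within the scatter).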

Compound 4, a percentage reported as inhibition, at one concentration (the size of the read-out at that concentration, not a potency): 48%
Beside the measured number, compound 4's estimate is 28 percentage points above it; measured number outside the range, below it.
By their numbers in this assay, from the lowest: compound 4; then compound 1; then compounds 3 and 2 (each within the scatter of the next).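

In this assay, tert-butyl in place of allyl on a nitrogen on an aromatic ring gives a number 30 percentage points lower from compound 1 to compound 4 (beyond the scatter), so a change at this site alters the read-out beyond the scatter even when no ring enters or leaves. Read with the earlier step of a number 19 percentage points higher from compound 1 to compound 2 (beyond the scatter), the same site now moves the number in both directions on the shared core: upward with 4-chlorophenyl in place of vinyl on the chain, downward with tert-butyl in place of allyl. Nothing on hand speaks to the reason for the lower number of compound 4, and the step stands as an observation only.

Compound 4 exchanges the double bond of allyl and the open chain for a branched group in a single change, and the two remain unseparated; a straight propyl chain or a cyclopropyl group on the same nitrogen would pull them apart. Also open, on these data alone, is how this read-out responds to a polar end on that nitrogen, such as an amine or a carboxylic acid carried on a longer chain.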